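The source may report more compounds than this note shows. Statements on the series, on what has been measured and on what is new or still open speak of the compounds shown alone.

Notes on the series. Compound 1 `C/C(=C\c1cc(-c2ccccc2)cs1)C(N)=O` carries a six-membered aromatic ring of carbon only without further substitution; compound 2 `C/C(=C\c1cc(-c2ccc(C)cc2)cs1)C(N)=O` and compound 3 `C/C(=C\c1cc(-c2ccc(F)cc2)cs1)C(N)=O` each vary one position on that ring. In an ADME assay on NIH3T3 cells (Mus musculus) for cytotoxicity, read by CCK-8 assay, with a stated time of 24 h (on this read-out lower numbers stand for stronger inhibition and higher numbers for weaker inhibition), compound 1 gives > 50000 nM, which is a limit of the assay and not a number. In this assay compound 2 gives > 50000 nM, again only a limit. In this assay compound 3 gives > 50000 nM, also a limit. All three values sit at the limit of > 50000 nM in this assay, at which 3 of the 3 values shown sit. The steps a step that the two limits leave unreadable from compound 1 to compound 2, a step that the two limits leave unreadable from compound 1 to compound 3 and a step that the two limits leave unreadable from compound 2 to compound 3 therefore cannot be sized in either direction. Compound 4 `C/C(=C\c1cc(-c2ccccc2C)cs1)C(N)=O` differs from compound 1 by methyl in place of hydrogen on an aromatic carbon. Among the measured compounds shown here, the steps that bear on this change, a methyl or a fluoro entering the same ring, are the unreadable ones, so no direction can be read from them. Compound 4 is accordingly expected to remain at the limit, with an estimate of 80000 nM in a range from 30000 nM to 300000 nM. The step that the limit leaves unreadable from compound 1 to compound 4 is thus expected to be none beyond the scatter, and most likely to be reported only as a limit.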

Compound 4, half-maximal inhibitory concentration: > 50000 nM
Compound 4 ended at the assay's limit; the forecaster's own chance of this, stated with the estimate: 85%; the middle value does not contradict the limit.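

No step from compound 1 to compound 4 can be read in this assay, because both compounds give a limit and not a number: the limit of > 50000 nM in this assay, at which 4 of the 4 values shown sit.

The compounds shown leave open whether a methyl or fluoro on the six-membered aromatic ring changes the result in this assay at all.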